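A Larger Group on Compound 3's Carbonyl

The compounds below may be only part of what the source reports. "The series", "measured", "known", "first", "only" and "open" are said of these compounds alone.

Measured in a functional assay (mast cells) with Rattus norvegicus as the target; a higher number here means a weaker inhibitor, a lower number a stronger inhibitor:
- Compound 1 `Oc1nnc(-c2nc3cc(Cl)ccc3o2)o1`: 350 nM
- Compound 2 `Cc1ccc2oc(-c3nnc(O)o3)nc2c1`: 400 nM
- Compound 3 `CC(=O)n1nc(-c2nc3ccccc3o2)oc1=O`: 1400 nM

Compound 3 has the highest number of the three, and its gaps to compound 1 and compound 2 both lie beyond the scatter. It is therefore the weakest inhibitor so far.

Compound 4 `O=C(/C=C/c1ccccc1)n1nc(-c2nc3ccccc3o2)oc1=O` differs from compound 3 in one place: 2-phenylethenyl in place of methyl on a carbonyl carbon. In words, 2-phenylethenyl stands in place of methyl on a carbonyl carbon.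

For the measured compounds named here, only one measured step links two compounds through a single change, a 1.1-fold higher number from compound 1 to compound 2 (0.06 log units; within the scatter). That step put methyl in place of chloro on an aromatic carbon, not on a carbonyl carbon, so it offers only weak guidance. Going by the values given here, no measured step shows what a change at this carbonyl carbon does in this assay. No direction can be read from the data, so no shift beyond the scatter is expected, though the uncertainty is wide.

The expected step is a 1.1-fold higher number from compound 3 to compound 4 (0.03 log units; within the scatter). Compound 4 is estimated at 1500 nM, with an expected range from 400 nM to 5000 nM.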

Compound 4, half-maximal inhibitory concentration: 15000 nM
The estimate for compound 4 lay 10-fold (1.00 log units) below the measured number; the measured number lies above the stated range.
By their numbers in this assay, from the lowest: compounds 1 and 2 (each within the scatter of the next); then compound 3; then compound 4.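

In this assay, the carbonyl carbon proves to be a position where a change of group can have a large effect: 2-phenylethenyl in place of methyl gives an 11-fold higher number from compound 3 to compound 4 (1.03 log units; beyond the scatter), a clear move toward weaker inhibition. For the compounds shown here, the only earlier single change, on an aromatic carbon, gave a 1.1-fold higher number from compound 1 to compound 2 (0.06 log units; within the scatter) and stayed within the scatter, so it gave no hint of a step this size. Nothing available explains this step.

From the compounds shown here alone, with only methyl and 2-phenylethenyl seen on this carbonyl, it remains open whether the ring, the double bond or the overall length of the new group accounts for the step. An ethyl group, a phenyl ring attached directly to the carbonyl, or a saturated 2-phenylethyl chain could help separate these features.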